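A few compounds are considered here, and "the series" means these few. Any claim that something is new, unique, unknown or untested is made for them only; others in the source may bear on it.

Measured in a functional assay on HepG2 cells (Homo sapiens) for cytotoxicity, read by MTT assay, with a stated time of 24 h; a higher number here means a weaker inhibitor, a lower number a stronger inhibitor:
- compound 1 `CN1C/C(=C\c2ccc(C#N)cc2)C(=O)/C(=C/c2ccccc2F)C1`: 590 nM
- compound 2 `CN1C/C(=C\c2ccc(Cl)cc2)C(=O)/C(=C/c2ccc(C#N)cc2)C1`: 5950 nM
- compound 3 `CN1C/C(=C\c2ccc(Br)cc2)C(=O)/C(=C/c2ccc(C#N)cc2)C1`: 4840 nM

Compound 3 sits at the high end of these three numbers, level with its chloro analogue: a 1.2-fold lower number from compound 2 to compound 3 (0.09 log units; within the scatter). The gap to the 2-fluorophenyl analogue is much larger: an 8.2-fold higher number from compound 1 to compound 3 (0.91 log units; beyond the scatter). The chloro analogue shows a similar gap: a 10-fold higher number from compound 1 to compound 2 (1.00 log units; beyond the scatter).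

The next compound is compound 4 `CN1C/C(=C\c2ccc(C#N)cc2)C(=O)/C(=C/c2ccc(Cl)cc2Cl)C1`, which carries 2,4-dichlorophenyl in place of 4-bromophenyl on a double-bonded chain carbon bound to a double-bonded ring carbon. Going by the values given here, no measured compound carries this group. It resembles both the 2-fluorophenyl of compound 1 at 590 nM and the 4-bromophenyl of compound 3 at 4840 nM, so a number between these two is expected in this assay. The expected change is a partial version of the larger measured steps, towards a lower number: a 2.8-fold lower number from compound 3 to compound 4 (0.45 log units; beyond the scatter). The estimate for compound 4 is 1700 nM. The expected range for compound 4 runs from 500 nM to 5500 nM.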

Compound 4, half-maximal inhibitory concentration: 6250 nM
Compound 4: the middle estimate sits 3.7-fold (0.57 log units) below what was measured; the measured number lies above the stated range.
By their numbers in this assay, from the lowest: compound 1; then compounds 3, 2 and 4 (each within the scatter of the next).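

In this assay, a 2,4-dichlorophenyl at this place reads level with the single-halogen phenyl groups (a 1.3-fold higher number from compound 3 to compound 4 (0.11 log units; within the scatter)), and chloro in place of hydrogen on the aromatic carbon of the phenyl group leaves the number unmoved (a 1.1-fold higher number from compound 2 to compound 4 (0.02 log units; within the scatter)). Carrying more than one halogen therefore does not bring this phenyl group towards the number of compound 1, which stays apart from the dichloro analogue (an 11-fold higher number from compound 1 to compound 4 (1.03 log units; beyond the scatter)), so among these compounds only the 2-fluorophenyl stands apart. No supporting measurement explains this separation.

As far as these compounds go, it remains open whether the lower number follows the fluoro group specifically, since a 2-chlorophenyl or a 4-fluorophenyl would separate the halogen from its place on the ring. Also open, from the compounds shown here alone, is how this place responds to a non-halogen group, such as an amine or a carboxylic acid on the phenyl ring.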